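The compounds below may be only part of what the source reports. "The series", "measured", "known", "first", "only" and "open" are said of these compounds alone.

Compound 1 `C=C1C[C@]23C[C@@]1(O)CC[C@H]2c1ccc(OS(=O)(=O)c2ccc(C)cc2)c(C)c1[C@@H]3Cn1cc(-c2ccc(OC)cc2)nn1` is the starting point of this step. In a functional assay on SW480 cells (Homo sapiens) for cytotoxicity, read by MTT assay, with a stated time of 4 days (on this read-out higher numbers stand for weaker inhibition and lower numbers for stronger inhibition), compound 1 returns only a limit, > 20000 nM, so no number places it. Compound 2 `C=C1C[C@]23C[C@@]1(O)CC[C@H]2c1ccc(O)c(C)c1[C@@H]3Cn1cc(-c2ccc(OC)cc2)nn1` differs from it by hydrogen in place of (4-methylphenyl)sulfonyl on an oxygen on an aromatic ring. In this assay compound 2 likewise stops at a limit, > 20000 nM. The step that the two limits leave unreadable from compound 1 to compound 2 is therefore of unreadable size. Compound 3 `Cc1ccc(-c2cn(C[C@H]3c4c(ccc(O)c4C)[C@@H]4CC[C@@]5(C)C[C@]43CC5=O)nn2)cc1` is a further member of the series. In this assay compound 3 also gives a limit, > 20000 nM. All three values thus sit together at the limit of > 20000 nM in this assay, at which 3 of the 3 values shown sit.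

Compound 4 `C=C1C[C@]23C[C@@]1(O)CC[C@H]2c1ccc(OS(=O)(=O)c2ccc(C)cc2)c(C)c1[C@@H]3Cn1cc(-c2ccc(C(F)(F)F)cc2)nn1` is the next entry, differing from compound 1 by trifluoromethyl in place of methoxy on an aromatic carbon
that is, 4-methoxyphenyl to 4-(trifluoromethyl)phenyl on the triazole side. Among the measured compounds shown here, no measured step touches this position; the only measured step, a step that the two limits leave unreadable from compound 1 to compound 2, concerns another place and is itself unreadable. Since every value rests at the limit of > 20000 nM in this assay, at which 3 of the 3 values shown sit, the step that the limit leaves unreadable from compound 1 to compound 4 is expected to show nothing beyond the scatter. The expected value for compound 4 is 30000 nM, between 10000 nM and 100000 nM, most likely reported again as a limit.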

Compound 4, half-maximal inhibitory concentration: > 20000 nM
Compound 4: no number, only a limit; the forecaster's own chance of this, stated with the estimate: 85%; the middle value does not contradict the limit.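

In this assay compound 4 gives > 20000 nM and this is a limit. Among the compounds shown here, compound 1 also rests at a limit, so no step between compound 1 and compound 4 can be read. The compounds shown leave open whether any change to the shared core yields a number in this assay at all, with every value resting at one place: the limit of > 20000 nM in this assay, at which 4 of the 4 values shown sit.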